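From amino to carboxy on the shared core

This account rests on a few compounds, and the source may have more. Where it says the series, first, only, none or still open, it means among the compounds named here.

Compound 2 (`Nc1ccc(C(=O)/C=C/c2ccc3c(c2)B(O)OC3)cc1`) stands at a limit and not at a number: in an ADME assay on L929 cells (Mus musculus) for cytotoxicity, read by resazurin assay, with a stated time of 72 h (on this read-out lower numbers stand for stronger inhibition and higher numbers for weaker inhibition), compound 2 gives > 10 ug/mL as a limit of the assay. Compound 1 (`O=C(/C=C/c1ccc2c(c1)B(O)OC2)c1ccc(OCc2ccccc2)cc1`) gives > 10 ug/mL in this assay and this too is a limit. The record so far is the limit of > 10 ug/mL in this assay, at which 2 of the 2 values shown sit, and it holds no number. Among the compounds with values here, the one measured step that bears on the change is a step that the two limits leave unreadable from compound 1 to compound 2 for amino in place of benzyloxy on an aromatic carbon, and it offers no size to carry forward. Compound 3 (`O=C(O)c1ccc(C(=O)/C=C/c2ccc3c(c2)B(O)OC3)cc1`) has carboxy in place of amino on an aromatic carbon, para to a large group, and the full difference is carboxy in place of amino on an aromatic carbon in this one place. With no size to go on, no step beyond the scatter is expected in this assay and no direction is favoured. The expected size is a step that the limit leaves unreadable from compound 2 to compound 3 on this estimate. Compound 3 is estimated at 20 ug/mL with 10 ug/mL to 50 ug/mL as the expected range.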

Compound 3, half-maximal inhibitory concentration: > 10 ug/mL
Compound 3: a limit, no number; the forecaster's own chance of this, stated with the estimate: 85%; the middle value does not contradict the limit.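

In this assay, within the data shown here, compound 3 gives > 10 ug/mL, which is a limit of the assay and not a number, so no step among compound 1, compound 2 and compound 3 can be read. The compounds shown leave open whether these three differ at all in this read-out, and by how much.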